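Replacing Methyl by 2-Fluorophenyl at the Sulfonyl Sulfur

The compounds below may be only part of what the source reports. "The series", "measured", "known", "first", "only" and "open" are said of these compounds alone.

In an assay on cells for inhibition of HSP60/HSP10 (Homo sapiens), with a stated time of 60 min (on this read-out higher numbers stand for weaker inhibition and lower numbers for stronger inhibition), the three measured compounds stand as follows.
Compound 1, `O=S(=O)(Nc1ccc(-c2nc3ccccc3o2)cc1)c1cccc(F)c1`, gives 71000 nM.
Compound 2, `Cc1ccc(S(=O)(=O)Nc2ccc(-c3nc4ccccc4o3)cc2)cc1`, gives > 100000 nM, which is a limit of the assay.
Compound 3, `CS(=O)(=O)Nc1ccc(-c2nc3ccccc3o2)cc1`, gives > 100000 nM, likewise a limit of the assay and not a number.

Compound 3 therefore has no measured number of its own in this assay; it sits at the limit of > 100000 nM in this assay, at which 2 of the 3 values shown sit, and only compound 1 provides a real value. The change to compound 4, `O=S(=O)(Nc1ccc(-c2nc3ccccc3o2)cc1)c1ccccc1F`, is 2-fluorophenyl in place of methyl on a sulfonyl sulfur. Within the data shown here, two measured steps bear on it. The step of an at least 1.4-fold higher number from compound 1 to compound 3 (0.14 log units; that floor lies within the scatter) goes the opposite way, from a fluorophenyl to methyl, and the step of an at least 1.4-fold higher number from compound 1 to compound 2 (0.14 log units; that floor lies within the scatter) exchanges one aryl group for another. The step that the two limits leave unreadable from compound 2 to compound 3 offers nothing readable. Returning a fluorophenyl group to the sulfonyl sulfur is thus expected to bring compound 4 back toward the region of compound 1, giving an estimated step of an at least 1.2-fold lower number from compound 3 to compound 4 (0.09 log units; that floor lies within the scatter) in this assay. Compound 4 is accordingly estimated at 80000 nM, with a range from 30000 nM to 200000 nM, and a real chance that this assay again reports only a limit.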

Compound 4, half-maximal inhibitory concentration: > 100000 nM
Compound 4 gave a limit, no number; the forecaster's own chance of this, stated with the estimate: 40%; middle value at least 1.2-fold (0.09 log units) from the limit.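

Putting 2-fluorophenyl in place of methyl on the sulfonyl sulfur leaves compound 4 at the limit, so a fluorophenyl group at this place is not enough on its own to give a readable number in this assay: the limit of > 100000 nM in this assay, at which 3 of the 4 values shown sit. Among the four compounds, compound 1, which carries 3-fluorophenyl, remains the only one with a real value, 71000 nM. Exchanging the two fluorophenyl groups gives an at least 1.4-fold higher number from compound 1 to compound 4 (0.14 log units; that floor lies within the scatter), which does not establish a true difference between them, and the steps among compound 2, compound 3 and compound 4 cannot be read, as each of those three values is a limit.

Going by these compounds, it remains open whether the true value of compound 4 lies close to that of compound 1 or far from it, and how compound 2, compound 3 and compound 4 rank among themselves. Also open, on these data alone, is how a 3-methoxyphenyl, a 3-aminophenyl or a 3-carboxyphenyl group on the sulfonyl sulfur would stand, and whether any group at this place can give a number clearly lower than that of compound 1.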